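The source may hold more compounds than are shown below. What is called first, only, known or untested is meant among the compounds shown, and "the series" means these compounds.

Measured so far:
compound 1, `C=C1[C@@H](CCC2=CCOC2=O)[C@]2(C)CC[C@@H](O)[C@@](C)(CO)[C@H]2C[C@@H]1O` — 25200 nM
compound 2, `C=C1CC[C@@H]2[C@](C)(CO)[C@H](O)CC[C@@]2(C)[C@@H]1C[C@H](O)[C@@H]1C(=O)OC[C@H]1O` — 24400 nM

In a functional assay on HL-60 cells (Homo sapiens) for antiproliferative activity, read by trypan blue exclusion (on this read-out lower numbers stand for stronger inhibition of growth and higher numbers for weaker inhibition of growth), compound 1 gives 25200 nM, the higher of the two numbers recorded, but compound 2 sits within the scatter of it at 24400 nM, so no order between the two is claimed. Both read as weak inhibitors of growth.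

Compound 3, `C=C1CC[C@@H]2[C@](C)(CO)[C@H](O)CC[C@@]2(C)[C@@H]1CCC1=CCOC1=O`, is not yet measured. Against compound 1 the change is hydrogen in place of hydroxy on a saturated ring carbon. Going by the values given here, no step between measured compounds of this kind is available for comparison, so the size of the step must be expected rather than read off. The change removes a single hydroxy from the core without touching the lactone side chain; a step from compound 1 to compound 3 that stays within the usual scatter, in either direction, is the expectation. The estimate for compound 3 is therefore 20000 nM, with a range from 8000 nM to 50000 nM, which corresponds to an expected step of a 1.3-fold lower number from compound 1 to compound 3 (0.10 log units; within the scatter).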

Compound 3, concentration for 50% growth inhibition: 25500 nM
The estimate for compound 3 lay 1.3-fold (0.11 log units) below the measured number, within the range that was stated.
By their numbers in this assay, from the lowest: compounds 2, 1 and 3 (each within the scatter of the next).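

Hydrogen in place of hydroxy on this saturated ring carbon gives a 1.0-fold higher number from compound 1 to compound 3 (0.01 log units; within the scatter) in this assay, the first step in the series that isolates a single place. With the lactone side chain unchanged, the number in this assay therefore does not depend on the hydroxy at this ring carbon, at least on the core of compound 1. This says nothing about the other hydroxy groups of the core, and no independent data bear on why the swap leaves the number within the scatter.

On these data alone, whether any group at this ring carbon can move the number beyond the scatter remains open, for instance an amine, a carboxylic acid or a methoxy. Also open, as far as these compounds go, is whether the same swap would read alike with the side chain of compound 2 in place of the lactone side chain of compound 1.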